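A few compounds are considered here, and "the series" means these few. Any claim that something is new, unique, unknown or untested is made for them only; others in the source may bear on it.

Measured compounds:

Compound 1, `O=S(=O)(c1ccc(F)c(Cl)c1)c1cnc2c(F)cccc2c1-c1cccc(Cl)c1`: 0.18 mL/min
Compound 2, `O=S(=O)(c1cc(Cl)cc(Cl)c1)c1cnc2c(F)cccc2c1-c1cccc(Cl)c1`: 1.2 mL/min
Compound 3, `O=S(=O)(c1ccc(F)c(Cl)c1)c1cnc2cc(F)ccc2c1-c1ccc(F)cc1`: 0.69 mL/min

All three were tested in an ADME assay on microsomes from liver (Homo sapiens) for metabolic stability, tested at 2.5 uM; on this read-out higher numbers stand for fast clearance and lower numbers for slow clearance. Compound 1 and compound 2 share one core and differ in a single place: 3,5-dichlorophenyl in place of 3-chloro-4-fluorophenyl on a sulfonyl sulfur. That change brought a 6.7-fold higher number from compound 1 to compound 2 (0.82 log units; beyond the scatter). Compound 3 sits on a different core, and the difference between the two cores is not broken down here. Compound 3 and compound 2 give numbers that lie within the scatter of each other in this assay, so nothing can be said about an order between them, while compound 3 and compound 1 are separated by more than the scatter.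

Compound 4, `O=S(=O)(c1cc(Cl)cc(Cl)c1)c1cnc2cc(F)ccc2c1-c1ccc(F)cc1`, has not been measured. It relates to compound 3 exactly as compound 2 relates to compound 1: 3,5-dichlorophenyl in place of 3-chloro-4-fluorophenyl on a sulfonyl sulfur. The surroundings of the change, a sulfonyl sulfur whose other neighbour is an aromatic carbon, are the same in both pairs, so this is the same change, made a second time on a different core.

The expectation for compound 4 rests on that one earlier instance. For the measured compounds named here, since a 6.7-fold higher number from compound 1 to compound 2 (0.82 log units; beyond the scatter) was the only time this change has been seen, and since a change can play out differently on another core, a step of similar direction but somewhat smaller size is estimated: a 4.3-fold higher number from compound 3 to compound 4 (0.64 log units; beyond the scatter). On that basis compound 4 is expected to give about 3 mL/min in this assay, most likely somewhere between 1.2 mL/min and 8 mL/min.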

Compound 4, intrinsic clearance in a liver preparation (reported as CLH), per the amount of preparation that the assay uses: 0.18 mL/min
Compound 4: the middle estimate sits 17-fold (1.22 log units) above what was measured; measured number below the stated range.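

In this assay, putting 3,5-dichlorophenyl in place of 3-chloro-4-fluorophenyl on the sulfonyl sulfur gave a 3.8-fold lower number from compound 3 to compound 4 (0.58 log units; beyond the scatter), so on this core the number fell rather than rose. Set beside the only other instance of the same change, the two steps run in opposite directions and clearly differ: the same change on two cores in this assay, a 6.7-fold higher number (0.82 log units; beyond the scatter) from compound 1 to compound 2 and a 3.8-fold lower number (0.58 log units; beyond the scatter) from compound 3 to compound 4, 26-fold (1.41 log units) apart, beyond the scatter of two such steps This shows that, for these two pairs, neither the size nor the direction of the change carried over from one core to the other, so a step seen on one core was a poor guide to the step on the other; it does not show which feature of the two cores lies behind the reversal, nor how the change would behave on any further core.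

Still open, from the compounds shown here alone, is whether a third core would follow the rise from compound 1 to compound 2, the fall from compound 3 to compound 4, or neither, and a core differing from compound 3 in only one place would help to pin the reversal down. The aromatic groups shown on the sulfonyl sulfur carry only chlorine and fluorine, so it also remains open how this read-out would respond to an amine or a carboxylic acid on that ring.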